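This account rests on a few compounds, and the source may have more. Where it says the series, first, only, none or still open, it means among the compounds named here.

Compound 3 `CCOC(=O)c1c(CSc2cccc(Cl)c2)n(C)c2ccc(O)cc12` stands at the edge of what the measurement reports. Going by the values given here, in an assay on cells for inhibition of Polyunsaturated fatty acid 5-lipoxygenase (Homo sapiens), read by HPLC, with a stated time of 15 min (a lower number here means a stronger inhibitor, a higher number a weaker inhibitor), compound 3 gives > 10000 nM, which is a limit of the assay and not a number, and it is the one value among the three that sits there (the limit of > 10000 nM in this assay, at which 1 of the 3 values shown sits). The two methoxy analogues carry numbers: compound 1 `CCOC(=O)c1c(CSc2ccccc2OC)n(C)c2ccc(O)cc12` gives 5100 nM in this assay, and compound 2 `CCOC(=O)c1c(CSc2ccc(OC)cc2)n(C)c2ccc(O)cc12` gives 3100 nM. The step of an at least 1.9-fold higher number from compound 1 to compound 3 (0.29 log units; that floor lies within the scatter) and the step of an at least 3.2-fold higher number from compound 2 to compound 3 (0.50 log units; beyond the scatter) both run toward the limit, while the step of a 1.6-fold lower number from compound 1 to compound 2 (0.22 log units; within the scatter) stays within the scatter. Compound 4 `CCOC(=O)c1c(CSc2c(C)cccc2C)n(C)c2ccc(O)cc12` differs from compound 3 in one place: 2,6-dimethylphenyl in place of 3-chlorophenyl on a sulfur. Among the compounds with values here, no measured step exchanges a 3-chlorophenyl for a 2,6-dimethylphenyl on the sulfur, so none bears directly on this change; the steps ending at compound 3 only show that the 3-chlorophenyl analogue reaches the limit, and the methoxy analogues fall short of it by modest margins. Compound 4 is therefore expected to give 9000 nM in this assay, within a range from 3000 nM to 25000 nM, which corresponds to an estimated step of an at least 1.1-fold lower number from compound 3 to compound 4 (0.04 log units; that floor lies within the scatter).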

Compound 4, half-maximal inhibitory concentration: 1200 nM
Beside the measured number, compound 4's estimate is 7.5-fold (0.88 log units) above it; measured number outside the range, below it.
By their numbers in this assay, from the lowest: compound 4; then compounds 2 and 1 (each within the scatter of the next). At a limit, above all of these: compound 3.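

Going by these compounds alone, the aryl group on the sulfur can move the number down as well as up, and in this assay the 2,6-dimethylphenyl gives the first downward changes beyond the scatter: a 2.6-fold lower number from compound 2 to compound 4 (0.41 log units; beyond the scatter) and a 4.3-fold lower number from compound 1 to compound 4 (0.63 log units; beyond the scatter). Against the 3-chlorophenyl the change can be stated only as a floor, an at least 8.3-fold lower number from compound 3 to compound 4 (0.92 log units; beyond the scatter). Compound 3 itself remains at a limit of the assay, not a number: the limit of > 10000 nM in this assay, at which 1 of the 4 values shown sits.

The compounds shown leave open how an unsubstituted phenyl, a cyclohexyl or a pyridyl on the sulfur would read in this assay, and so whether the methyl groups of the 2,6-dimethylphenyl are needed for the lower number. They also leave open whether a naphthyl there would lower the number further or raise it again.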